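A Ring Swap on the Oxygen of Compound 2

A few compounds are considered here, and "the series" means these few. Any claim that something is new, unique, unknown or untested is made for them only; others in the source may bear on it.

Measured in a functional assay on Jurkat cells (Homo sapiens) for inhibition; on this read-out lower numbers stand for stronger inhibition and higher numbers for weaker inhibition:
- Compound 1 `CC(C)c1cc(OCC(=O)[C@H](CC(=O)O)NC(=O)[C@@H](NC(=O)COc2cccc3ccccc23)C(C)C)no1` gives > 200000 nM, a limit of this assay rather than a number.
- Compound 2 `COC(=O)c1cc(OCC(=O)[C@H](CC(=O)O)NC(=O)[C@@H](NC(=O)COc2cccc3ccccc23)C(C)C)no1` gives 71000 nM.
- Compound 3 `CC(C)[C@H](NC(=O)COc1cccc2ccccc12)C(=O)N[C@@H](CC(=O)O)C(=O)CSc1nc[nH]n1` gives > 200000 nM, again a limit.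

Compound 2 therefore stands as the only number shown; the other two values are limits. Changing a group on the ring of compound 1 gave an at least 2.8-fold lower number from compound 1 to compound 2 (0.44 log units; beyond the scatter). Replacing that whole ring gave an at least 2.8-fold higher number from compound 2 to compound 3 (0.44 log units; beyond the scatter), while the comparison a step that the two limits leave unreadable from compound 1 to compound 3.

Compound 4 `Cc1cc(OCC(=O)[C@H](CC(=O)O)NC(=O)[C@@H](NC(=O)COc2cccc3ccccc23)C(C)C)nc(C)n1` has not been measured. 2,6-dimethylpyrimidin-4-yl in place of 5-(methoxycarbonyl)-1,2-oxazol-3-yl on an oxygen on a saturated carbon This change again replaces the whole ring on the oxygen, as in the step to compound 3, which ended at the limit of > 200000 nM in this assay, at which 2 of the 3 values shown sit. The expectation is therefore a weaker or at best similar number, with a real chance that only a limit is returned. The expected step is a 2.1-fold higher number from compound 2 to compound 4 (0.32 log units; beyond the scatter). For compound 4 the estimate is 150000 nM, between 40000 nM and 400000 nM.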

Compound 4, half-maximal inhibitory concentration: > 200000 nM
Compound 4: a limit, no number; the forecaster's own chance of this, stated with the estimate: 45%; at least 1.3-fold (0.12 log units) between middle value and limit.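

Replacing the ring while keeping the oxygen still costs activity in this assay, with an at least 2.8-fold higher number from compound 2 to compound 4 (0.44 log units; beyond the scatter); the step to compound 3 had changed the oxygen to sulfur as well, so the oxygen alone does not preserve a measurable value. Among the three compounds with this oxygen, only compound 2, the one carrying methoxycarbonyl, gives a number, while the isopropyl of compound 1 and the two methyl groups of compound 4 do not. The steps from compound 3 to compound 4 and from compound 1 to compound 4 cannot be read, and most of the series stays at the assay's ceiling: the limit of > 200000 nM in this assay, at which 3 of the 4 values shown sit.

This swap removes the methoxycarbonyl and the 1,2-oxazole ring together, so the contribution of each remains unseparated. Also open, from the compounds shown here alone, is whether a carboxylic acid or a primary amide on the 1,2-oxazole ring, or a methoxycarbonyl on the pyrimidine ring, would give a stronger number than compound 2.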